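The source may report more compounds than this note shows. Statements on the series, on what has been measured and on what is new or still open speak of the compounds shown alone.

Compound 1 `CCn1c(C(=O)N[C@@H](C)C(=O)OC)ccc1C(CC)(CC)c1ccc(OCS(=O)(=O)c2ccccc2)c(C)c1` was examined in a functional assay on PC-3 cells (Homo sapiens) for antiproliferative activity, read by MTT assay, with a stated time of 24 h; on this read-out higher numbers stand for weaker inhibition and lower numbers for stronger inhibition. In this assay compound 1 gives only a limit, > 50000 nM, and no number. Compound 2 `CCn1c(C(=O)NCCC(=O)OC)ccc1C(CC)(CC)c1ccc(OCS(=O)(=O)c2ccccc2)c(C)c1` differs from compound 1 in one place, and in this assay compound 2 gives 40400 nM. The step of an at least 1.2-fold lower number from compound 1 to compound 2 (0.09 log units; that floor lies within the scatter) is the only measured one here, and it rests on the limit at the limit of > 50000 nM in this assay, at which 1 of the 2 values shown sits, rather than on two numbers. Compound 3 `CCn1c(C(=O)NCCNC(=O)OC(C)(C)C)ccc1C(CC)(CC)c1ccc(OCS(=O)(=O)c2ccccc2)c(C)c1` has not yet been measured in this assay. It differs from compound 1 by 2-((tert-butoxycarbonyl)amino)ethyl in place of 1-(methoxycarbonyl)ethyl on an amide-type nitrogen. This change shares with the step to compound 2 the loss of 1-(methoxycarbonyl)ethyl, but the group that enters, 2-((tert-butoxycarbonyl)amino)ethyl, matches nothing that has been measured. Going by the values given here, since the single available step, an at least 1.2-fold lower number from compound 1 to compound 2 (0.09 log units; that floor lies within the scatter), begins at a limit and has a floor within the scatter, the data give no direction for the change to compound 3. Compound 1 stands at the limit of this assay. Compound 3 is therefore expected to remain near that limit, with a step of an at least 1.1-fold lower number from compound 1 to compound 3 (0.04 log units; that floor lies within the scatter) that means nothing beyond the scatter. The estimate for compound 3 in this assay is 45000 nM, between 20000 nM and 150000 nM, with a fair chance that only a limit is reported again.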

Compound 3, half-maximal inhibitory concentration: > 50000 nM
Compound 3: only a limit was reported; the forecaster's own chance of this, stated with the estimate: 50%; middle value at least 1.1-fold (0.04 log units) away from the limit.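

In this assay compound 3 gives > 50000 nM, which is a limit and not a number. Going by these compounds alone, the one readable comparison at this position is an at least 1.2-fold higher number from compound 2 to compound 3 (0.09 log units; that floor lies within the scatter), with (tert-butoxycarbonyl)amino in place of methoxycarbonyl on the chain, and since its floor lies within the scatter, it shows no real separation even though the entering group carries one hydrogen-bond donor more by the count. The step between compound 1 and compound 3 cannot be read, so exchanging 1-(methoxycarbonyl)ethyl for 2-((tert-butoxycarbonyl)amino)ethyl on the amide-type nitrogen gives no direction, and the series now rests mostly on one limit: the limit of > 50000 nM in this assay, at which 2 of the 3 values shown sit.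

The compounds shown leave open whether any group on this amide-type nitrogen can bring the number clearly away from that limit. Compound 2 alone gives a number, 40400 nM. Going by these compounds, it also remains open how a chain ending in a free primary amine or a carboxylic acid, in place of the protected amine or the methyl ester, would read in this assay.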